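The source may hold more compounds than are shown below. What is called first, only, known or untested is meant among the compounds shown, and "the series" means these compounds.

Measured so far in a functional assay on HL-60 cells (Homo sapiens) for antiproliferative activity (a higher number here means a weaker inhibitor of growth, a lower number a stronger inhibitor of growth), all three as limits:

- Compound 1 `COC(=O)CCCCCCCCCCCCCC/C=C1\CC(CO)(COC(=O)C(C)(C)C)OC1=O`: > 10 ug/mL
- Compound 2 `CC(C)(C)C(=O)OCC1(CO)C/C(=C\CCCCCCCCCCCO)C(=O)O1`: > 10 ug/mL
- Compound 3 `CC(=O)OCCCCCCCCCCCCCCC/C=C1\CC(CO)(COC(=O)C(C)(C)C)OC1=O`: > 10 ug/mL

Compound 3 stands at > 10 ug/mL, which is a limit and not a number. It therefore marks no exact place on the scale, and the same is true of its two companions.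

Compound 4 `CC(C)(C)C(=O)OCCCCCCCCCCCCCCC/C=C1\CC(CO)(COC(=O)C(C)(C)C)OC1=O` carries tert-butyl in place of methyl on a carbonyl carbon, so the acetoxy end of the chain in compound 3 becomes ((tert-butyl)carbonyl)oxy: tert-butyl in place of methyl on a carbonyl carbon.

Within the data shown here, three measured steps bear on this change at the chain end: a step that the two limits leave unreadable from compound 1 to compound 2, a step that the two limits leave unreadable from compound 1 to compound 3 and a step that the two limits leave unreadable from compound 2 to compound 3. None of them has a size to carry over, because of the limit of > 10 ug/mL in this assay, at which 3 of the 3 values shown sit. Changes at this end of the chain have so far produced no readable result in this assay, so no clear step in either direction is expected, and another limit is the likeliest report. The expected outcome is a step that the limit leaves unreadable from compound 3 to compound 4. Compound 4 is estimated at 15 ug/mL, with an expected range from 6 ug/mL to 40 ug/mL.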

Compound 4, concentration for 50% growth inhibition: 7.78 ug/mL
Beside the measured number, compound 4's estimate is 1.9-fold (0.29 log units) above it; measured number inside the range.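

In this assay, compound 4 is the first compound shown to give a number and not a limit, so a ((tert-butyl)carbonyl)oxy chain end is the one end group here with a readable value. The comparisons give an at least 1.2-fold lower number from compound 3 to compound 4 (0.10 log units; that floor lies within the scatter), an at least 1.2-fold lower number from compound 2 to compound 4 (0.10 log units; that floor lies within the scatter) and an at least 1.2-fold lower number from compound 1 to compound 4 (0.10 log units; that floor lies within the scatter). Each is only a floor, and the true size of each step cannot be read, because the other compound in each pair has only a limit: the limit of > 10 ug/mL in this assay, at which 3 of the 4 values shown sit.

As far as these compounds go, how far compound 1, compound 2 and compound 3 really lie from compound 4 remains open, as does whether the change to tert-butyl lowers the number at all. Also open, from the compounds shown here alone, is what a carboxylic acid or an amine at this chain end would give in this assay.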